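This account rests on a few compounds, and the source may have more. Where it says the series, first, only, none or still open, it means among the compounds named here.

In a functional assay (Saphenous vein) with Canis familiaris (Canis lupus familiaris) as the target (a higher number here means a more potent compound, by a factor of ten per unit of this negative logarithm, a lower number a less potent compound), compound 1 `CCOc1ccc(NC(=O)c2ccc(OC)c(CCCN(C)C)c2)cc1` gives 6.9, while compound 2 `COCCOC(=O)c1ccc(-c2ccc(NC(=O)c3ccc(OC)c(CCCN(C)C)c3)cc2)c(C)c1` gives 8.4. For the measured compounds named here, compound 2 therefore holds the higher of the only two numbers so far, and the gap between them lies beyond the usual scatter. Compound 3 `COc1ccc(C(=O)Nc2ccc(-c3ccc(C(=O)O)cc3C)cc2)cc1CCCN(C)C` keeps the rest of compound 2 and makes one change: hydrogen in place of 2-methoxyethyl on an oxygen next to a carbonyl group. Put another way, (2-methoxyethoxy)carbonyl becomes carboxy. The two measured compounds differ in more than one place, so neither of their numbers isolates this change, and any forecast remains a judgement. A fall in potency beyond the scatter is expected, with an estimated a number 1.00 log units lower from compound 2 to compound 3 (beyond the scatter). For compound 3, the estimated value is 7.4, with an expected range from 6.6 to 8.2.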

Compound 3, negative logarithm of the antagonist equilibrium constant: 8.7
Compound 3: the middle estimate sits 1.30 log units below what was measured; the whole stated range lies below it.
By their numbers in this assay, from the lowest: compound 1; then compounds 2 and 3 (each within the scatter of the next).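

In this assay, putting hydrogen in place of 2-methoxyethyl on an oxygen next to a carbonyl group turns (2-methoxyethoxy)carbonyl into carboxy and gives a number 0.30 log units higher from compound 2 to compound 3 (within the scatter). The 2-methoxyethyl chain is therefore not needed to hold the potency of compound 2, since the simple carboxy form reads the same within the scatter. The large step lies in the other place: 4-carboxy-2-methylphenyl in place of ethoxy on an aromatic carbon gives a number 1.80 log units higher from compound 1 to compound 3 (beyond the scatter), so the high potency does not depend on keeping the ester.

Nothing available explains why these two groups read alike. On these data alone, how a methyl ester or a primary amide would read at this position remains open, as does what the methyl group of 4-carboxy-2-methylphenyl contributes on its own.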